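The compounds below may be only part of what the source reports. "The series", "measured", "known", "first", "only" and "open" are said of these compounds alone.

Three compounds with a shared core have been examined in a functional assay on MIA PaCa-2 cells (Homo sapiens) for inhibition, read by MTT assay, with a stated time of 48 h, tested at 10 uM; a lower number here means less inhibition of growth, a higher number more inhibition of growth at the concentration tested. Compound 1 `Cc1cc(=O)c2c(O)cc(OCc3ccco3)c([C@H]3CCN(C)C[C@H]3O)c2o1` gives 7% in this assay. Compound 2 `Cc1cc(=O)c2c(O)c(CN3CCC(c4ccccc4)CC3)c(O)c([C@H]3CCN(C)C[C@H]3O)c2o1` gives 16% in this assay. Compound 3 `Cc1oc2c([C@H]3CCN(C)C[C@H]3O)c(O)cc(O)c2c(=O)c1C(O)c1cccc(Cl)c1` gives 2% in this assay, the lowest of the three numbers; the gap to compound 1 lies within the usual scatter of this measurement, so the two cannot be told apart, while the gap to compound 2 lies beyond it.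

The next compound, compound 4 `Cc1oc2c([C@H]3CCN(C)C[C@H]3O)c(O)cc(O)c2c(=O)c1C(O)c1cccc(Cl)c1Cl`, has not yet been measured in this assay. It differs from compound 3 in a single place: chloro in place of hydrogen on an aromatic carbon. Among the measured compounds shown here, no step between two measured compounds of this set involves a change of this kind, so nothing in the numbers above speaks directly to it. With compound 3 sitting near the bottom of a low-inhibition range, and a single chloro in place of hydrogen being a small change, the step from compound 3 to compound 4 is expected to be small, a number 4 percentage points higher from compound 3 to compound 4 (within the scatter), and not beyond the scatter in either direction. Compound 4 is therefore estimated to give about 6% in this assay, with a plausible range from 0% to 20%.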

Compound 4, percent growth inhibition at one concentration: 2%
Estimate against measurement, compound 4: 4 percentage points above; low and high end bracket the measured number.
By their numbers in this assay, from the lowest: compounds 3, 4, 1 and 2 (each within the scatter of the next, the first and the last beyond it).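

Read as a single change, chloro in place of hydrogen on an aromatic carbon, taking 3-chlorophenyl to 2,3-dichlorophenyl within the (3-chlorophenyl)(hydroxy)methyl group, gives in this assay no change at the digits printed from compound 3 to compound 4 (within the scatter). Among the compounds shown here, this is the first step in the set between two measured compounds that differ in one place, and it shows that a chloro at this place, ortho to a chloro group and ortho to a large group, leaves growth inhibition where it was, with compound 4 at 2%. No measurement is at hand that would account for this result.

For the compounds shown here, what a methoxy group, an amine or a carboxylic acid would do at this same place remains open, since chloro is the only group that this single step covers. Also open, as far as these compounds go, is whether the same chloro in place of hydrogen would still leave the number unmoved on a compound that stands higher in this assay, as compound 3 and compound 4 both lie at the low end of the range seen so far.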